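Swapping the Sulfonyl Aryl in a Fluoroquinoline Sulfone Series

The source may hold more compounds than are shown below. What is called first, only, known or untested is meant among the compounds shown, and "the series" means these compounds.

Measured compounds:
Compound 1 `COc1ccc(-c2c(S(=O)(=O)c3cc(F)cc(F)c3)cnc3c(F)cccc23)cc1` — 2.59 mL/min
Compound 2 `O=S(=O)(c1cc(F)cc(F)c1)c1cnc2c(F)cccc2c1-c1cccc(Cl)c1` — 0.64 mL/min
Compound 3 `N#Cc1cccc(S(=O)(=O)c2cnc3c(F)cccc3c2-c2cccc(F)c2)c1` — 0.34 mL/min

Three compounds sharing one core have been run in an ADME assay on microsomes from liver (Homo sapiens) for metabolic stability, tested at 2.5 uM; a higher number here means faster removal of the compound, a lower number slower removal. Compound 1 gives 2.59 mL/min, compound 2 gives 0.64 mL/min and compound 3 gives 0.34 mL/min. Compound 3 thus carries the lowest of the three numbers in this assay; its gap to compound 2 lies within the scatter, while its gap to compound 1 lies beyond it.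

Within the data shown here, the one measured step is a 4.0-fold lower number from compound 1 to compound 2 (0.61 log units; beyond the scatter), which concerns the aryl group on the aromatic carbon, not the sulfonyl side.

Compound 4 `O=S(=O)(c1cc(F)cc(F)c1)c1cnc2c(F)cccc2c1-c1cccc(F)c1` has not yet been measured. It differs from compound 3 by 3,5-difluorophenyl in place of 3-cyanophenyl on a sulfonyl sulfur. Among the measured compounds shown here, no measured step touches the sulfonyl aryl, so the change has no direct precedent. What can be said is that compound 2, which already carries a 3,5-difluorophenyl on the sulfonyl sulfur, gives 0.64 mL/min, and that compound 3 gives 0.34 mL/min, the two sitting within the scatter of each other.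

Compound 4 is therefore expected to land close to these, with a 1.5-fold higher number from compound 3 to compound 4 (0.17 log units; within the scatter) not beyond the scatter. The estimate for compound 4 in this assay is 0.5 mL/min, with a range from 0.25 mL/min to 1.1 mL/min.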

Compound 4, intrinsic clearance in a liver preparation (reported as CLH), per the amount of preparation that the assay uses: 1.18 mL/min
Estimate against measurement, compound 4: 2.4-fold (0.37 log units) below, outside the stated range (above it).
By their numbers in this assay, from the lowest: compounds 3, 2 and 4 (each within the scatter of the next, the first and the last beyond it); then compound 1.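

In this assay, the change on the sulfonyl sulfur, 3,5-difluorophenyl in place of 3-cyanophenyl, gives a 3.5-fold higher number from compound 3 to compound 4 (0.54 log units; beyond the scatter) with 3-fluorophenyl held on the aromatic carbon, which shows that the number responds to the sulfonyl aryl as well as to the aryl on the aromatic carbon. With 3,5-difluorophenyl held on the sulfonyl sulfur, fluoro in place of chloro gives a 1.8-fold higher number from compound 2 to compound 4 (0.27 log units; within the scatter) and so does not separate the two halogens, while 3-fluorophenyl in place of 4-methoxyphenyl gives a 2.2-fold lower number from compound 1 to compound 4 (0.34 log units; beyond the scatter) and so moves the number in the same direction as 3-chlorophenyl did in that place. No measurement at hand accounts for any of these steps.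

On these data alone, the sulfonyl change rests on one pair of compounds, so whether it would be of similar size with 3-chlorophenyl or 4-methoxyphenyl on the aromatic carbon remains open. Also open, as far as these compounds go, is how this assay would respond to an amine or a carboxylic acid on the sulfonyl aryl, or to an unsubstituted phenyl on the sulfonyl sulfur.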